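The compounds below may be only part of what the source reports. "The series", "measured", "known", "first", "only" and "open" are said of these compounds alone.

Measured compounds:
compound 1, `CN1C(=S)N(C2CCCCC2)C(=O)/C1=C\c1ccc(N(C)CCCO)cc1`, giving 1190 nM in an assay on isolated protein for inhibition of NADPH oxidase 4 (Homo sapiens), read by chemiluminescence, in the presence of a further agent that is not named here; a higher number here means a weaker inhibitor, a lower number a stronger inhibitor;
compound 2, `CN1C(=S)N(c2ccccc2)C(=O)/C1=C\c1ccc(N(C)CCCO)cc1`, giving 3390 nM in this assay;
compound 3, `CN1C(=S)N(C2CCCCC2)C(=O)/C1=C\c1ccc(N(C)C)cc1O`, giving 2350 nM in this assay.

Compound 1 and compound 2 share a core and differ in one place: phenyl in place of cyclohexyl on an amide-type nitrogen in a ring. This change produced a 2.8-fold higher number from compound 1 to compound 2 (0.45 log units; beyond the scatter). Compound 3 carries a different core; how it differs from compound 1 is not broken down here. Compound 3 stands near compound 2 in this assay, and its values against compound 1 and compound 2 fall within the usual scatter, so no order among them is claimed.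

Compound 4, `CN1C(=S)N(c2ccccc2)C(=O)/C1=C\c1ccc(N(C)C)cc1O`, has not yet been measured. It arises from compound 3 by the same kind of change: phenyl in place of cyclohexyl on an amide-type nitrogen in a ring. Both "place" descriptions read alike word for word. Because the earlier step of a 2.8-fold higher number from compound 1 to compound 2 (0.45 log units; beyond the scatter) was modest, the step from compound 3 to compound 4 is expected to be of a similar size, a 2.6-fold higher number from compound 3 to compound 4 (0.41 log units; beyond the scatter). Compound 4 is therefore estimated to give 6000 nM in this assay, with an expected range from 2500 nM to 15000 nM.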

Compound 4, half-maximal inhibitory concentration: 3430 nM
Compound 4: middle estimate off by 1.7-fold (0.24 log units), on the high side; low and high end bracket the measured number.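

Carried to the second core, phenyl in place of cyclohexyl on an amide-type nitrogen in a ring gave a 1.5-fold higher number from compound 3 to compound 4 (0.16 log units; within the scatter) in this assay. Set beside the earlier step, this one cannot be told apart from it: the same change on two cores in this assay, a 2.8-fold higher number (0.45 log units; beyond the scatter) from compound 1 to compound 2 and a 1.5-fold higher number (0.16 log units; within the scatter) from compound 3 to compound 4, 2.0-fold (0.29 log units) apart, within the scatter of two such steps. The result fits a single modest step carrying over from one core to the other, but it does not prove one, since the step stands clear of the scatter on one core only and two pairs are too few to set a rule for the series.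

The compounds shown leave open how other groups on that nitrogen would read, such as a benzyl group, a short alkyl chain or a phenyl ring bearing a fluorine or a methoxy group. They also leave open whether the same change holds on a core carrying a carboxylic acid or a primary amine in place of the hydroxyl group.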